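A few compounds are considered here, and "the series" means these few. Any claim that something is new, unique, unknown or untested is made for them only; others in the source may bear on it.

Compound 1, `O=C1[C@@H](NS(=O)(=O)c2ccc(-c3ccccn3)s2)CCN1Cc1cc2[nH]cccc-2n1`, gives 8%.
Compound 2, `O=C1[C@@H](NS(=O)(=O)c2ccc(-c3ccccn3)s2)CCN1Cc1cc2c[nH]ccc-2n1`, gives 11%.
Compound 3, `O=C1[C@@H](NS(=O)(=O)c2ccc(-c3ccccn3)s2)CCN1Cc1cc2cc[nH]cc-2n1`, gives 17%.

In an assay on isolated protein for inhibition of coagulation factor X (Oryctolagus cuniculus), tested at 1 uM (on this read-out higher numbers stand for more inhibition at the one concentration tested (going by the name of the read-out) and lower numbers for less inhibition), compound 1 shows the smallest of the three numbers, yet the steps of a number 3 percentage points higher from compound 1 to compound 2 (within the scatter) and a number 9 percentage points higher from compound 1 to compound 3 (within the scatter) both stay within the scatter, so the three compounds cannot be told apart. Compound 4, `O=C1[C@@H](NS(=O)(=O)c2ccc(-c3ccon3)s2)CCN1Cc1cc2[nH]cccc-2n1`, is reached from compound 1 by one change: 1,2-oxazol-3-yl in place of pyridin-2-yl on an aromatic carbon. Within the data shown here, none of the measured steps touches this part of the molecule; each of them swaps the group on the saturated chain carbon bound to the amide-type nitrogen, and each stayed within the scatter. Among the measured compounds shown here, no measured step therefore bears on this change, and no movement beyond the scatter is expected. Compound 4 is estimated at 8%, with a range from 0% to 25%, which means an expected step of no change at the digits printed from compound 1 to compound 4 (within the scatter).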

Compound 4, a percentage reported as inhibition, at one concentration (the size of the read-out at that concentration, not a potency): 31%
The estimate for compound 4 lay 23 percentage points below the measured number, and the stated range ends below it.
By their numbers in this assay, from the lowest: compounds 1, 2 and 3 (each within the scatter of the next); then compound 4.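

In this assay, 1,2-oxazol-3-yl in place of pyridin-2-yl on the aromatic carbon next to the ring sulfur gives a number 23 percentage points higher from compound 1 to compound 4 (beyond the scatter) and is the only step shown that passes the scatter. This position can therefore shift the read-out, whereas the swaps on the saturated chain carbon could not be told apart. No measurement here explains the shift.

The entering ring differs in both size and hetero atoms, so the compounds shown do not separate these two differences. A phenyl or 1,3-thiazol-2-yl group at this position could help separate them.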